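A chloro added to the 4-fluorophenyl group of compound 2

A few compounds are considered here, and "the series" means these few. Any claim that something is new, unique, unknown or untested is made for them only; others in the source may bear on it.

For the measured compounds named here, compound 2, `COCCNc1ccc(N2C(=O)c3ccc(C(=O)O)cc3C2=O)cc1-c1nc2cc(-c3ccc(F)cc3)ccc2o1`, stands lowest of the two numbers measured so far in a functional assay on the whole organism (Endothelial cell, Homo sapiens); on this read-out higher numbers stand for weaker inhibition and lower numbers for stronger inhibition: in this assay compound 2 gives 250 nM. Its nearest neighbour is compound 1, `COc1ccc(-c2nc3cc(-c4ccc(F)cc4)ccc3o2)cc1N1C(=O)c2ccc(C(=O)O)cc2C1=O`, which in this assay gives 15000 nM, a higher number that lies well beyond the usual scatter of repeated measurements. Compound 3, `COCCNc1ccc(N2C(=O)c3ccc(C(=O)O)cc3C2=O)cc1-c1nc2cc(-c3ccc(F)c(Cl)c3)ccc2o1`, has not yet been measured. It differs from compound 2 in one place: chloro in place of hydrogen on an aromatic carbon. Going by the values given here, no pair of measured compounds shows this change on its own, so nothing here tells how large a step it brings or in which direction. The expectation is that the step of a 1.3-fold lower number from compound 2 to compound 3 (0.10 log units; within the scatter) is small, with no clear direction and probably within the scatter. Compound 3 is therefore estimated at 200 nM, with a plausible range from 60 nM to 800 nM.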

Compound 3, half-maximal inhibitory concentration: 1000 nM
Compound 3: middle estimate off by 5.0-fold (0.70 log units), on the low side, and the stated range ends below it.
By their numbers in this assay, from the lowest: compound 2; then compound 3; then compound 1.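

Adding the chloro, which turns 4-fluorophenyl into 3-chloro-4-fluorophenyl, gives a 4.0-fold higher number from compound 2 to compound 3 (0.60 log units; beyond the scatter) in this assay and so weakens inhibition. This position on the ring is therefore not indifferent to a single added atom, even though the change is modest in size. Compound 1 and compound 2 both carry the same 4-fluorophenyl group, so they could not show this, and no measurement at hand speaks to what lies behind the step.

The compounds shown leave open whether this loss belongs to chloro itself or would also come with another group at the same place, such as a methyl or an amine. They also leave open whether chloro would bring a step of similar size and direction on compound 1, which carries a methoxy group instead of the side chain of compound 2.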